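This account rests on a few compounds, and the source may have more. Where it says the series, first, only, none or still open, it means among the compounds named here.

Of the compounds shown here, three have been measured in a functional assay on HeLa cells (Homo sapiens), read by colorimetric assay, with a stated time of 72 h; a lower number here means that less compound is needed, a higher number that more compound is needed for the effect. Compound 1 `CC(=O)OC[C@H]1O[C@@H](n2cc(CBr)nn2)[C@H](OC(C)=O)[C@@H](OC(C)=O)[C@@H]1OC(C)=O` gives 3.5 ug/mL, compound 3 `CC(=O)OC[C@H]1O[C@@H](n2nncc2CBr)[C@H](OC(C)=O)[C@@H](OC(C)=O)[C@@H]1OC(C)=O` gives 4 ug/mL, and compound 2 `CC(=O)N[C@@H]1[C@@H](OC(C)=O)[C@H](OC(C)=O)[C@@H](COC(C)=O)O[C@H]1n1cc(CBr)nn1` gives 20 ug/mL. Compound 2 therefore stands at the highest number of the three, needing more material than either of the others: the nearest is compound 3, and a 5.7-fold higher number from compound 1 to compound 2 (0.76 log units; beyond the scatter) shows the step from the lowest number.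

The two measured steps tell of two different changes. From compound 1 to compound 2 the change is an acetamido in place of an acetoxy on a saturated ring carbon. From compound 1 to compound 3 the bromomethyl moves to the other carbon of the triazole, and a 1.1-fold higher number from compound 1 to compound 3 (0.06 log units; within the scatter) shows no shift beyond the scatter.

Compound 4 `CC(=O)N[C@@H]1[C@@H](OC(C)=O)[C@H](OC(C)=O)[C@@H](COC(C)=O)O[C@H]1n1nnc(CO)c1CO` asks a new question: 4,5-bis(hydroxymethyl)-1H-1,2,3-triazol-1-yl in place of 4-(bromomethyl)-1H-1,2,3-triazol-1-yl on a saturated ring carbon. Among the compounds with values here, no measured step replaces the bromomethyl with hydroxymethyl groups, so the two steps above give only a weak guide. With the shared core and the acetamido held as in compound 2, a higher number is expected for compound 4, by a step of a 3.0-fold higher number from compound 2 to compound 4 (0.48 log units; beyond the scatter), as an estimate rather than a reading. The expected value for compound 4 is 60 ug/mL, within a range from 15 ug/mL to 250 ug/mL.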

Compound 4, concentration for half-maximal effect: > 100 ug/mL
Compound 4 gave a limit, no number; the forecaster's own chance of this, stated with the estimate: 30%; middle value at least 1.6-fold (0.22 log units) away from the limit.
By their numbers in this assay, from the lowest: compounds 1 and 3 (each within the scatter of the next); then compound 2. At a limit, above all of these: compound 4.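

Among the earlier compounds, the only change on the triazole was a move of the bromomethyl, read as a 1.1-fold higher number from compound 1 to compound 3 (0.06 log units; within the scatter), so the group itself had stayed the same. Compound 4 changes the group at this position on the saturated ring carbon next to the ring oxygen, with 4,5-bis(hydroxymethyl)-1H-1,2,3-triazol-1-yl in place of 4-(bromomethyl)-1H-1,2,3-triazol-1-yl, and this change does register, as an at least 5.0-fold higher number from compound 2 to compound 4 (0.69 log units; beyond the scatter). In this assay compound 4 gives > 100 ug/mL, which is a limit and not a number, so the size of this step has only a lower bound: the limit of > 100 ug/mL in this assay, at which 1 of the 4 values shown sits.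

The change removes the bromine and adds a second hydroxymethyl group in one step, so the compounds shown cannot say how much of the shift belongs to each part, and a triazole with a single hydroxymethyl, or with an aminomethyl group, would separate these questions. Going by these compounds, it also remains open whether the same replacement has a similar effect with an acetoxy group in place of the acetamido group, as in the core of compound 1.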